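The source may report more compounds than this note shows. Statements on the series, on what has been measured and on what is new or still open speak of the compounds shown alone.

Compound 1 `COC(=O)N[C@H](C(=O)NN(CC[C@@](O)(Cc1ccccc1)C(=O)N[C@H]1c2ccccc2C[C@H]1O)Cc1ccc(-c2cccnc2)cc1)C(C)(C)C`: 4900 nM
Compound 2 `COC(=O)N[C@H](C(=O)NN(CC[C@@](O)(Cc1ccccc1)C(=O)N[C@H]1c2ccccc2C[C@H]1O)Cc1ccc(-c2ccncc2)cc1)C(C)(C)C`: > 10000 nM, a limit
Compound 3 `COC(=O)N[C@H](C(=O)NN(CC[C@@](O)(Cc1ccccc1)C(=O)N[C@H]1c2ccccc2C[C@H]1O)Cc1ccc(-c2cc(F)cc(F)c2)cc1)C(C)(C)C`: > 10000 nM, a limit

In an ADME assay on MT4 cells (Homo sapiens) for cytotoxicity, read by XTT assay, with a stated time of 5 days (a lower number here means that less compound is tolerated, a higher number that more compound is tolerated), compound 3 gives > 10000 nM, which is a limit of the assay and not a number. This is the limit of > 10000 nM in this assay, at which 2 of the 3 values shown sit. Compound 4 `COC(=O)N[C@H](C(=O)NN(CC[C@@](O)(Cc1ccccc1)C(=O)N[C@H]1c2ccccc2C[C@H]1O)Cc1ccccc1)C(C)(C)C` carries hydrogen in place of 3,5-difluorophenyl on an aromatic carbon. The measured steps at that carbon only exchange one ring for another, and none leaves hydrogen there. They are an at least 2.0-fold higher number from compound 1 to compound 2 (0.30 log units; that floor lies within the scatter) and an at least 2.0-fold higher number from compound 1 to compound 3 (0.30 log units; that floor lies within the scatter), along with a step that the two limits leave unreadable from compound 2 to compound 3. From these, no step beyond the scatter is expected in this assay, and no direction can be favoured with confidence. The expected change is a step that the limit leaves unreadable from compound 3 to compound 4. For compound 4 the estimate is 12000 nM, with an expected range from 5000 nM to 30000 nM.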

Compound 4, half-maximal cytotoxic concentration: > 10000 nM
Compound 4 gave a limit, no number; the forecaster's own chance of this, stated with the estimate: 75%; the middle value does not contradict the limit.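

Among the compounds shown here, with hydrogen in place of a ring, this carbon is seen bare for the first time, and in this assay the change gives an at least 2.0-fold higher number from compound 1 to compound 4 (0.30 log units; that floor lies within the scatter). Compound 4 joins the others at a limit, which is not a number: the limit of > 10000 nM in this assay, at which 3 of the 4 values shown sit A ring on this carbon is therefore not needed to reach that limit, and the steps to compound 4 from compound 2 and compound 3 cannot be read.

Going by these compounds, only compound 1 has a true number, and how far the other compounds lie past the limit stays open. Also open, on these data alone, is what an amine or a carboxylic acid on this carbon would do.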